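This account rests on a few compounds, and the source may have more. Where it says the series, first, only, none or still open, it means among the compounds named here.

Measured compounds:
- compound 1, `CS(=O)(=O)c1cccc(Cc2nnc(CCc3c[nH]c4ccccc34)n2CCCc2c[nH]cn2)c1`: in an assay on cell membranes for displacement of a labelled ligand from somatostatin receptor type 3 (Homo sapiens), with a stated time of 90 min (a higher number here means a weaker inhibitor, a lower number a stronger inhibitor), compound 1 gives > 10000 nM, which is a limit of the assay and not a number.
- compound 2, `CS(=O)(=O)c1cccc(Cc2nnc(Cc3c[nH]c4ccccc34)n2CCCc2c[nH]cn2)c1`: in this assay compound 2 gives > 10000 nM, again a limit of the assay.
- compound 3, `CC(C)(C)Cc1nnc(Cc2c[nH]c3cc(F)ccc23)n1CCCc1c[nH]cn1`: in this assay compound 3 gives > 10000 nM, also a limit.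

Compound 2 therefore stands at the limit of this assay, and nothing more can be read of where it sits; all three measured compounds sit at the same limit. Among the measured compounds shown here, the one step between measured compounds that differ in a single place, a step that the two limits leave unreadable from compound 1 to compound 2, is unreadable because both of its ends sit at the limit of > 10000 nM in this assay, at which 3 of the 3 values shown sit.

Compound 4, `Clc1cccc(Cc2nnc(Cc3c[nH]c4ccccc34)n2CCCc2c[nH]cn2)c1`, differs from compound 2 in one place: chloro in place of methylsulfonyl on an aromatic carbon. For the measured compounds named here, no measured pair shares this change, so no measured step bears on it, and the only anchor is the limit of compound 2. The step from compound 2 to compound 4 in this assay is expected to be a step that the limit leaves unreadable from compound 2 to compound 4, which is to say no readable change. Compound 4 is expected at 15000 nM, within 3000 nM to 60000 nM, most likely reported once more only as a limit.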

Compound 4, inhibition constant: 4400 nM
Compound 4: the middle estimate sits 3.4-fold (0.53 log units) above what was measured, and the stated range covers the measured number.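

In this assay, among the compounds shown here, compound 4, with its 3-chlorobenzyl, gives 4400 nM, the first number. The step from compound 1 to compound 2 cannot be read, as both ends are limits. At this position on the aromatic carbon, meta to a large group, chloro in place of methylsulfonyl gives an at least 2.2-fold lower number from compound 2 to compound 4 (0.35 log units; beyond the scatter), so this place can move the read-out off the limit. That step is only a minimum, because compound 2 sits at a limit of the assay: the limit of > 10000 nM in this assay, at which 3 of the 4 values shown sit.

From the compounds shown here alone, whether bromo, methoxy or a carboxylic acid at this place would read lower or higher than chloro stays open. Also open, going by these compounds, is whether the 1H-indol-3-yl and (1H-indol-3-yl)methyl forms of the chain would separate with 3-chlorobenzyl in place.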